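This account rests on a few compounds, and the source may have more. Where it says the series, first, only, none or still open, it means among the compounds named here.

Measured so far in a functional assay on NCI-H3122 cells (Homo sapiens) for inhibition, read by CellTiter-Glo, with a stated time of 72 h; on this read-out higher numbers stand for weaker inhibition of growth and lower numbers for stronger inhibition of growth:
- compound 1 `C=CC(=O)Nc1cc(Nc2ncc(Cl)c(Nc3ccccc3S(=O)(=O)C(C)C)n2)c(OC)cc1N1CCN(S(C)(=O)=O)CC1`: its result is a limit of the assay rather than a number, < 0.3 nM
- compound 2 `C=CC(=O)Nc1cc(Nc2ncc(Cl)c(Nc3ccccc3S(=O)(=O)C(C)C)n2)c(OC)cc1N1CCN(C)CC1`: 33 nM
- compound 3 `C=CC(=O)Nc1cc(Nc2ncc(Cl)c(Nc3ccccc3S(=O)(=O)C(C)C)n2)c(OC)cc1N1CCCCC1`: 29 nM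

Among the two actual numbers, compound 2 gives the highest, and compound 3 sits nearest, at a 1.1-fold lower number from compound 2 to compound 3 (0.06 log units; within the scatter), so these two cannot be told apart. The other two measured steps were large: an at least 110-fold higher number from compound 1 to compound 2 (2.04 log units; beyond the scatter) and an at least 96-fold higher number from compound 1 to compound 3 (1.98 log units; beyond the scatter). Both of them change what hangs on the aromatic carbon, namely methyl in place of methylsulfonyl on the amine nitrogen in the ring, or piperidin-1-yl in place of 4-(methylsulfonyl)piperazin-1-yl; neither touches the sulfonyl sulfur.

Compound 4 `C=CC(=O)Nc1cc(Nc2ncc(Cl)c(Nc3ccccc3S(=O)(=O)N(C)C)n2)c(OC)cc1N1CCN(C)CC1` is the next compound to be measured. It differs from compound 2 in one place: dimethylamino in place of isopropyl on a sulfonyl sulfur. None of the measured steps concerns this sulfonyl sulfur, so there is no direct guide for the size of this step, and the measured data give no reason to expect a change beyond the scatter. The step from compound 2 to compound 4 is therefore expected to be about a 1.1-fold higher number from compound 2 to compound 4 (0.03 log units; within the scatter). For compound 4 the estimate in this assay is 35 nM, with a range from 10 nM to 120 nM.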

Compound 4, concentration for 50% growth inhibition: 11 nM
Beside the measured number, compound 4's estimate is 3.2-fold (0.50 log units) above it, within the range that was stated.
By their numbers in this assay, from the lowest: compound 4; then compounds 3 and 2 (each within the scatter of the next). At a limit, below all of these: compound 1.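

Among these compounds, the earlier steps all changed the group carrying the 4-methylpiperazin-1-yl or related ring, so this is the first view of what the sulfonyl sulfur contributes. In this assay, dimethylamino in place of isopropyl gives a 3.0-fold lower number from compound 2 to compound 4 (0.48 log units; beyond the scatter), a modest step, which shows that this position affects growth inhibition in these cells, even though the two groups have the same heavy-atom count and neither has a ring or a net charge. What does differ is that a nitrogen now stands on the sulfur where isopropyl had a carbon, but nothing measured here tells why the swap shifts the number.

A single swap on a single background leaves open how far this position can be pushed, for instance with a plain methyl, a longer chain such as n-butyl, or a ring amine such as pyrrolidin-1-yl on the sulfonyl sulfur. Going by these compounds, it also remains open whether the same swap would give a step of similar size when 4-methylpiperazin-1-yl is replaced by piperidin-1-yl or by 4-(methylsulfonyl)piperazin-1-yl.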